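Hydroxyamino replacing hydroxy on the carboxyl of compound 1

The compounds below may be only part of what the source reports. "The series", "measured", "known", "first", "only" and "open" are said of these compounds alone.

Three compounds of the series have a number in a functional assay, tested at 100 uM; on this read-out higher numbers stand for a stronger effect at the one concentration tested and lower numbers for a weaker effect. Compound 1 `COc1ccc(Cn2cc(C(=O)O)c(=O)c3ccccc32)cc1OC` gives 32.2% in this assay. Compound 2 `COc1cc(Cn2cc(C(=O)O)c(=O)c3ccccc32)cc(OC)c1` gives 47.6% in this assay, a number that lies beyond the scatter above that of compound 1. Compound 3 `O=C(NO)c1cn(Cc2ccc(Br)cc2)c2ccccc2c1=O` gives 27.6% in this assay, which sits within the scatter of the number of compound 1. Compound 1 thus stands in the middle of the three numbers, close to compound 3 and clearly under compound 2. Among the compounds with values here, no pair of these measured compounds differs in a single place, so no measured step can be drawn on.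

The next compound, compound 4 `COc1ccc(Cn2cc(C(=O)NO)c(=O)c3ccccc32)cc1OC`, differs from compound 1 in one place: hydroxyamino in place of hydroxy on a carbonyl carbon. Compound 3 carries the same hydroxycarbamoyl group and gives 27.6%, not far from compound 1, but it also differs elsewhere, so it is only a rough pointer.

Within the data shown here, with no measured step of this kind, the change from compound 1 to compound 4 is expected to stay within the scatter, with no clear direction, the expected step being a number 2.2 percentage points lower from compound 1 to compound 4 (within the scatter). For compound 4 the estimate in this assay is 30%, with a range from 15% to 45%.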

Compound 4, a percentage reported as activity, at one concentration (the size of the read-out at that concentration, not a potency): 39.1%
The estimate for compound 4 lay 9.1 percentage points below the measured number; the measured number falls inside the stated range.
By their numbers in this assay, from the lowest: compounds 3, 1, 4 and 2 (each within the scatter of the next, the first and the last beyond it).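

In this assay the change from carboxy to hydroxycarbamoyl now has a direct reading on the core of compound 1, free of the other differences that made compound 3 only a rough pointer: the step is a number 6.9 percentage points higher from compound 1 to compound 4 (within the scatter) and stays within the usual scatter. At the one concentration tested, this position on the carbonyl carbon therefore accepts hydroxyamino in place of hydroxy with no clear gain or loss, so the read-out does not depend on the free carboxy group in this single pair. Nothing available bears on why the step has this size.

Within the data shown here, still open is whether the same change reads alike on other benzyl substitution patterns, such as the one in compound 2, since a single pair gives no trend and a single-concentration read-out gives no potency. Also open, as far as these compounds go, is how other groups on this carbonyl carbon would read, for instance a plain amine forming a primary amide, a methoxyamino group or a methoxy group forming a methyl ester.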